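A few compounds are considered here, and "the series" means these few. Any claim that something is new, unique, unknown or untested is made for them only; others in the source may bear on it.

Compound 1, with the structure `CCC(CC)N(CCN(C)C(=O)CCC(=O)O)Cc1cccc(C(=O)Nc2sc3c(c2C(=O)c2cnn(-c4ccc(Cl)c(C(F)(F)F)c4)c2)CCC(C)(C)C3)c1`, belongs to the same series, but in an assay on isolated protein for inhibition of sodium-dependent phosphate transport protein 2B (Rattus norvegicus) (on this read-out lower numbers stand for stronger inhibition and higher numbers for weaker inhibition), compound 1 gives "nd" (no result reported), meaning that no result was reported for it, so it contributes no number. Going by the values given here, compound 2, with the structure `CCC(CC)N(CCN(C)C(=O)CCC(=O)NCCOCCOCCOCCO)Cc1cccc(C(=O)Nc2sc3c(c2C(=O)c2cnn(-c4ccc(Cl)c(C(F)(F)F)c4)c2)CCC(C)(C)C3)c1`, gives 2.1 nM in this assay, and that is the only measured value in the set: there is no second number to place it against and no step between measured compounds to read off.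

Compound 3, with the structure `CCC(CC)N(CCN(C)C(=O)CCC(=O)NC(C)(C)C(=O)NCCN(C)C)Cc1cccc(C(=O)Nc2sc3c(c2C(=O)c2cnn(-c4ccc(Cl)c(C(F)(F)F)c4)c2)CCC(C)(C)C3)c1`, is the next member to be looked at. It differs from compound 2 in one place: a group of 11 heavy atoms (8 carbon, 2 nitrogen, 1 oxygen; no ring) in place of a group of 12 heavy atoms (8 carbon, 4 oxygen; no ring), on an amide-type nitrogen. Both groups are open chains of similar size, each carrying one hydrogen-bond donor, and the exchange sits on an amide-type nitrogen far from the shared core. With only the value of compound 2 to go by, the expectation for compound 3 is a step of no more than the usual scatter in this assay, with no clear direction, so the step from compound 2 to compound 3 is expected to be a 1.4-fold higher number from compound 2 to compound 3 (0.15 log units; within the scatter). Compound 3 is therefore estimated at 3 nM, with a likely range from 1 nM to 10 nM.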

Compound 3, half-maximal inhibitory concentration in the sodium-dependent phosphate transport protein 2B assay: 7.6 nM
Beside the measured number, compound 3's estimate is 2.5-fold (0.40 log units) below it; the range from low to high includes it.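

In the sodium-dependent phosphate transport protein 2B assay the position on the amide-type nitrogen proves not to be silent: replacing the group of 12 heavy atoms with 1-((2-(dimethylamino)ethyl)carbamoyl)-1-methylethyl gives a 3.6-fold higher number from compound 2 to compound 3 (0.56 log units; beyond the scatter), so the number does respond to what sits at this far end of the molecule, though the step is modest. In a physicochemical assay for solubility, in simulated intestinal fluid, at pH 5.1 (on this read-out lower numbers stand for lower solubility and higher numbers for higher solubility), compound 2 gives > 384 ug/mL, which is a limit of the assay and not a number. In the physicochemical assay compound 3 gives > 434 ug/mL, again a limit and not a number, and the step in this read-out therefore cannot be read.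

Nothing measured here bears on what lies behind the step in inhibition. The exchange replaces a whole chain at once, which leaves open whether the higher number goes with the dimethylamino end or with the 1-methylethyl carbon, and how a morpholine at the chain end, a chain ending in a hydroxyl without the 1-methylethyl carbon, or a longer chain would read in the sodium-dependent phosphate transport protein 2B assay.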